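The compounds below may be only part of what the source reports. "The series", "measured", "known", "first", "only" and "open" are said of these compounds alone.

Three compounds share a core and differ only in the group hanging from the amide. In an assay on HEK293 cells for displacement of a labelled ligand from NPC1-like intracellular cholesterol transporter 1 (Homo sapiens) (on this read-out higher numbers stand for weaker inhibition and lower numbers for stronger inhibition), compound 1 `CC(C)(C)c1ccc(C(=O)N2CCC3(CC2)C(=O)N(CC(=O)NCCCCO)CN3c2ccccc2)cc1` gives 19200 nM, compound 2 `CC(C)(C)c1ccc(C(=O)N2CCC3(CC2)C(=O)N(CC(=O)NCN)CN3c2ccccc2)cc1` gives 26500 nM, and compound 3 `CC(C)(C)c1ccc(C(=O)N2CCC3(CC2)C(=O)N(CC(=O)NCCCCCO)CN3c2ccccc2)cc1` gives 9400 nM, the lowest of the three and therefore the strongest inhibitor here, since a 2.0-fold lower number from compound 1 to compound 3 (0.31 log units; beyond the scatter) and a 2.8-fold lower number from compound 2 to compound 3 (0.45 log units; beyond the scatter) both exceed the scatter. Compound 4 `CC1CCCN(C(=O)CN2CN(c3ccccc3)C3(CCN(C(=O)c4ccc(C(C)(C)C)cc4)CC3)C2=O)C1` carries a different change at this position: 3-methylpiperidin-1-yl in place of (5-hydroxypentyl)amino on a carbonyl carbon. The measured steps all keep a chain with a donor; none removes it or closes a ring, so they only show this position tolerates modest shifts, and a 1.4-fold higher number from compound 1 to compound 2 (0.14 log units; within the scatter) was within the scatter. Compound 4 is therefore expected to move a 1.3-fold higher number from compound 3 to compound 4 (0.11 log units; within the scatter), with an estimate of 12000 nM (range 3000 nM to 45000 nM) in this assay.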

Compound 4, half-maximal inhibitory concentration: 12000 nM
Estimate against measurement, compound 4: no gap at the digits printed, within the range that was stated.
By their numbers in this assay, from the lowest: compounds 3, 4, 1 and 2 (each within the scatter of the next, the first and the last beyond it).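

The ring 3-methylpiperidin-1-yl, with 0 hydrogen-bond donors, can stand on this carbonyl carbon in place of chains that carry them, with a 1.3-fold higher number from compound 3 to compound 4 (0.11 log units; within the scatter) and a 1.6-fold lower number from compound 1 to compound 4 (0.20 log units; within the scatter) both within the scatter. So among these compounds a hydrogen-bond donor in this group is not needed for inhibition, and a 2.2-fold lower number from compound 2 to compound 4 (0.34 log units; beyond the scatter) is the only new step beyond the scatter. Nothing given here explains this result.

Still open, as far as these compounds go, is whether an unsubstituted piperidine or a morpholine would match 3-methylpiperidin-1-yl. A longer chain ending in a carboxylic acid is also an untested direction among the compounds shown.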